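Swapping the thiophene on compound 2

The compounds below may be only part of what the source reports. "The series", "measured", "known", "first", "only" and "open" are said of these compounds alone.

Within the data shown here, compound 2 `Cn1nc2c(=O)n(CC3(O)CCN(Cc4ccc(-c5cccs5)cc4Cl)CC3)cnc2c1-c1ccc(CN)cc1` gives the lowest number of the two measured so far in an assay on isolated protein for inhibition of ubiquitin carboxyl-terminal hydrolase 7 (Homo sapiens), with stated times of 30 min and 2 h (a higher number here means a weaker inhibitor, a lower number a stronger inhibitor), at 38.6 nM. Compound 1 `Cn1nc2c(=O)n(CC3(O)CCN(Cc4ccc(-c5n[nH]c(=O)o5)cc4Cl)CC3)cnc2c1-c1ccc(CN)cc1` gives 171 nM in this assay, and the step of a 4.4-fold lower number from compound 1 to compound 2 (0.65 log units; beyond the scatter) is the only one measured. Compound 3 `Cn1nc2c(=O)n(CC3(O)CCN(Cc4ccc(-c5ccsc5Cl)cc4Cl)CC3)cnc2c1-c1ccc(CN)cc1` differs from compound 2 by 2-chlorothiophen-3-yl in place of thiophen-2-yl on an aromatic carbon. Among the measured compounds shown here, that earlier step exchanged a ring with three hetero atoms for one with a single hetero atom, whereas here one thiophene replaces another, so no measured step bears directly on this change, and a step no larger than the scatter is expected, a 1.2-fold higher number from compound 2 to compound 3 (0.07 log units; within the scatter). Compound 3 is therefore estimated at 45 nM, with a range of 15 nM to 140 nM.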

Compound 3, half-maximal inhibitory concentration: 453 nM
Compound 3: the middle estimate sits 10-fold (1.00 log units) below what was measured; measured number outside the range, above it.
By their numbers in this assay, from the lowest: compound 2; then compound 1; then compound 3.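

In this assay, thiophene rings are not interchangeable at this position: 2-chlorothiophen-3-yl in place of thiophen-2-yl gives a 12-fold higher number from compound 2 to compound 3 (1.07 log units; beyond the scatter). The ring with a single hetero atom no longer holds the advantage seen earlier, with a 2.6-fold higher number from compound 1 to compound 3 (0.42 log units; beyond the scatter). Nothing available explains this loss.

The change adds a chlorine and also moves the thiophene's point of attachment, and the compounds shown do not separate these two effects. Plain thiophen-3-yl at this position would show how much each contributes.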